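The source may report more compounds than this note shows. Statements on the series, on what has been measured and on what is new or still open speak of the compounds shown alone.

Measured so far in a functional assay on SK-OV-3 cells (Homo sapiens) for inhibition, read by sulforhodamine B assay; on this read-out lower numbers stand for stronger inhibition of growth and higher numbers for weaker inhibition of growth:
compound 1 `Nc1ccc(CNC(=O)CC2c3ccccc3N=C(N3CCCCC3)N2c2ccccc2)cc1`, 39300 nM
compound 2 `CCN1C(N2CCCCC2)=Nc2ccccc2C1CC(=O)NCc1ccc(NS(=O)(=O)c2ccc(C)cc2)cc1`, 22800 nM

In this assay compound 2 and compound 1 sit within the usual scatter of each other, so the two numbers show no separation. Compound 3 `Cc1ccc(S(=O)(=O)Nc2ccc(CNC(=O)CC3c4ccccc4N=C(N4CCCCC4)N3c3ccccc3)cc2)cc1` follows from compound 2 by phenyl in place of ethyl on an amine nitrogen in a ring. Among the compounds with values here, no step between measured compounds is known for this change, and compound 1, which carries the phenyl on that nitrogen, gives a number within scatter of compound 2. The step of a 1.1-fold higher number from compound 2 to compound 3 (0.04 log units; within the scatter) is therefore expected to stay within the scatter, in no particular direction. For compound 3 the expected value is 25000 nM, with a range of 8000 nM to 80000 nM.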

Compound 3, concentration for 50% growth inhibition: 2930 nM
The estimate for compound 3 lay 8.5-fold (0.93 log units) above the measured number; measured number below the stated range.
By their numbers in this assay, from the lowest: compound 3; then compounds 2 and 1 (each within the scatter of the next).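

In this assay phenyl in place of ethyl on the amine nitrogen in a ring gives a 7.8-fold lower number from compound 2 to compound 3 (0.89 log units; beyond the scatter) and thus shows that this position matters when the (4-methylphenyl)sulfonyl group is present. With phenyl held on that nitrogen, (4-methylphenyl)sulfonyl in place of hydrogen on the nitrogen on the aromatic ring gives a 13-fold lower number from compound 1 to compound 3 (1.13 log units; beyond the scatter) and so also counts. Nothing available explains either step.

Open, going by these compounds, is whether benzyl or cyclohexyl on the ring nitrogen would match phenyl. Also open, on these data alone, is whether methanesulfonyl or acetyl could replace the (4-methylphenyl)sulfonyl group.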